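Bromo on the Benzamide Ring of a Weak Thiophene Series

The source may report more compounds than this note shows. Statements on the series, on what has been measured and on what is new or still open speak of the compounds shown alone.

In a functional assay on HeLa cells (Homo sapiens) for antiproliferative activity, with a stated time of 24 h (on this read-out higher numbers stand for weaker inhibition and lower numbers for stronger inhibition), compound 1 `NC(=O)c1c(NC(=O)c2ccccc2Cl)sc2c1CCN(Cc1cc(Cl)cc(Cl)c1)C2` gives 19600 nM. Placing (2-chlorophenyl)carbamoyl in place of 3,5-dichlorobenzyl on the amine nitrogen brought a 2.3-fold higher number from compound 1 to compound 2 (0.36 log units; beyond the scatter), so that compound 2 `NC(=O)c1c(NC(=O)c2ccccc2Cl)sc2c1CCN(C(=O)Nc1ccccc1Cl)C2` gives 45400 nM. Compound 3 `NC(=O)c1c(NC(=O)c2ccccc2)sc2c1CCN(C(=S)Nc1ccccc1Cl)C2` reaches only a limit of this assay, > 50000 nM, and therefore sits at the limit of > 50000 nM in this assay, at which 1 of the 3 values shown sits, without a number of its own. Compound 4 `NC(=O)c1c(NC(=O)c2ccccc2Br)sc2c1CCN(C(=S)Nc1ccccc1Cl)C2` differs from compound 3 by bromo in place of hydrogen on an aromatic carbon. Among the measured compounds shown here, no measured step touches this position, and the one measured step concerns a different part of the shared core, so there is no basis for any step beyond the scatter, and compound 4 is expected to show a number no higher from compound 3 to compound 4 (the limit leaves the size open). Compound 4 is therefore estimated at 50000 nM, between 20000 nM and 150000 nM, with a substantial chance of again reaching only the limit.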

Compound 4, half-maximal inhibitory concentration: 46900 nM
Compound 4: middle estimate off by 1.1-fold (0.03 log units), on the high side; measured number inside the range.
By their numbers in this assay, from the lowest: compound 1; then compounds 2 and 4 (each within the scatter of the next). At a limit, above all of these: compound 3.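

Benzoyl to (2-bromophenyl)carbonyl, bromo on an aromatic carbon ortho to a large group, brought an at least 1.0-fold lower number from compound 3 to compound 4 (0.02 log units; that floor lies within the scatter) and so provides the only step read at this position. Compound 3 gives > 50000 nM as a limit and not a number. The true size of the step stays unknown because one end of it is a limit: the limit of > 50000 nM in this assay, at which 1 of the 4 values shown sits.

From the compounds shown here alone, whether an amine or a methoxy group on the same carbon would move the number beyond the scatter stays open. So does what bromo would do with 3,5-dichlorobenzyl on the amine nitrogen.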